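A few compounds are considered here, and "the series" means these few. Any claim that something is new, unique, unknown or untested is made for them only; others in the source may bear on it.

Of the compounds shown here, three built on one shared core have been measured in a functional assay on BMDM cells (Mus musculus, strain C57BL/6) for inhibition, with a stated time of 2 days; a higher number here means a weaker inhibitor, a lower number a stronger inhibitor. Compound 1 `O=C(Cn1cc(-c2ccc(F)cc2)nn1)Nc1nccs1` gives 190 nM, the lowest of the three numbers. Compound 3 `Cc1csc(NC(=O)Cn2cc(-c3ccc(F)cc3)nn2)n1` gives 250 nM in this assay, and compound 2 `O=C(Cn1cc(-c2ccc([N+](=O)[O-])cc2)nn1)Nc1nccs1` gives 1040 nM. The step of a 1.3-fold higher number from compound 1 to compound 3 (0.12 log units; within the scatter) stays within the scatter, so compounds 1 and 3 cannot be told apart, whereas the step of a 5.5-fold higher number from compound 1 to compound 2 (0.74 log units; beyond the scatter) lies beyond it.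

Compound 4 `O=C(Cn1cc(-c2cccc(Cl)c2)nn1)Nc1nccs1` has not yet been measured. It differs from compound 1 in one place: 3-chlorophenyl in place of 4-fluorophenyl on an aromatic carbon. Among the compounds with values here, no measured step tries this exact change. The step from compound 1 to compound 3 touches a different part of the molecule. The step from compound 1 to compound 2 does alter the same phenyl ring, replacing only the fluoro with a nitro, and that was a modest change toward a higher number. The available data therefore give only loose guidance: a step of modest size, in either direction, is the expectation, with a slight lean toward a higher number. The expected step is a 1.6-fold higher number from compound 1 to compound 4 (0.20 log units; within the scatter). Compound 4 is estimated at 300 nM in this assay, with a likely range from 100 nM to 900 nM.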

Compound 4, half-maximal inhibitory concentration: > 30000 nM
Compound 4 gave a limit, no number (the forecaster's own chance of this, stated with the estimate: 5%); at least 100-fold (2.00 log units) between middle value and limit.
By their numbers in this assay, from the lowest: compounds 1 and 3 (each within the scatter of the next); then compound 2. At a limit, above all of these: compound 4.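

In this assay, compound 4 gives no number, only a limit of the assay: the limit of > 30000 nM in this assay, at which 1 of the 4 values shown sits. Within the data shown here, replacing 4-fluorophenyl with 3-chlorophenyl produces an at least 150-fold higher number from compound 1 to compound 4 (2.19 log units; beyond the scatter), a far larger step than a 5.5-fold higher number from compound 1 to compound 2 (0.74 log units; beyond the scatter), which was the only earlier change on this phenyl ring. Among these compounds, compound 2, with its nitro in place of the fluoro, still gives a measurable 1040 nM, so the earlier compounds suggested that this ring could accept a change and keep a readable result. Compound 4, by contrast, shows that a single change here can take the result to the limit of the assay.

Two things change together between compound 1 and compound 4, the halogen and its place on the ring, as the names 4-fluorophenyl and 3-chlorophenyl show, and the compounds shown cannot separate the two. That question would need 4-chlorophenyl and 3-fluorophenyl, while an amine or a carboxylic acid on this ring remains an open case as well.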